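From methoxymethyl to ethoxymethyl in a cell assay

This account rests on a few compounds, and the source may have more. Where it says the series, first, only, none or still open, it means among the compounds named here.

In a functional assay on KB cells (Homo sapiens) for inhibition (a higher number here means a weaker inhibitor, a lower number a stronger inhibitor), compound 1 (`CC(=O)OC1C(CCl)OC(n2c(Cl)nc3cc(Cl)c(Cl)cc32)C1OC(C)=O`) gives 90000 nM. Compound 2 (`COC[C@H]1OC(n2c(Cl)nc3cc(Cl)c(Cl)cc32)[C@H](O)[C@@H]1O`) gives 90000 nM, level with compound 1 at the digits reported. Among the compounds with values here, no measured pair yet shows what a single change does, so there is no direct guide to the size of the next step.

Compound 3 (`CCOC[C@H]1OC(n2c(Cl)nc3cc(Cl)c(Cl)cc32)[C@H](O)[C@@H]1O`) follows from compound 2 through one small change: methyl in place of hydrogen on a saturated chain carbon bound to an oxygen on a saturated carbon. This places methyl in place of hydrogen on a saturated chain carbon bound to an oxygen on a saturated carbon, turning methoxymethyl into ethoxymethyl. Within the data shown here, the only close reference is compound 2 at 90000 nM, and the change is small. The expected step, a 1.1-fold lower number from compound 2 to compound 3 (0.05 log units; within the scatter), therefore stays within the usual scatter, with no clear direction. For compound 3 the estimated value is 80000 nM, with an expected range from 35000 nM to 170000 nM.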

Compound 3, half-maximal inhibitory concentration: 80000 nM
Beside the measured number, compound 3's estimate shows no gap at the digits printed; low and high end bracket the measured number.
By their numbers in this assay, from the lowest: compounds 3, 1 and 2 (each within the scatter of the next).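

Within the data shown here, this is the first single change that can be read directly at this position. Extending methoxymethyl to ethoxymethyl, by putting methyl in place of hydrogen on a saturated chain carbon bound to an oxygen on a saturated carbon, gives a 1.1-fold lower number from compound 2 to compound 3 (0.05 log units; within the scatter) in this assay. This extra methyl therefore leaves the two compounds indistinguishable in this assay, so the position accepts this one added carbon without a readable shift in either direction. No accompanying measurement bears on why the number holds.

On these data alone, whether a longer chain, such as propoxymethyl, or an amine or a carboxylic acid at the end of this chain would move the number beyond the scatter remains open. A single step at one position also says nothing about changes elsewhere on the shared core.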